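A halogen swap on a compound without measurable cytotoxicity

The compounds below may be only part of what the source reports. "The series", "measured", "known", "first", "only" and "open" are said of these compounds alone.

Measured compounds:
compound 1 `Nc1cccc(/C=C2\SC(=O)N(Cc3cccc(F)c3)C2=O)c1` gives > 250000 nM in a functional assay on HeLa cells (Homo sapiens) for cytotoxicity, read by cell counting, with a stated time of 4 days (a lower number here means a stronger inhibitor, a higher number a weaker inhibitor), which is a limit of the assay and not a number.
compound 2 `Nc1ccc(/C=C2\SC(=O)N(Cc3cccc(F)c3)C2=O)cc1` gives 250000 nM in this assay.

Compound 1 therefore stands only at a limit in this assay, with no number of its own. Within the data shown here, the one measured step, a number no higher from compound 1 to compound 2 (the limit leaves the size open), has a size that cannot be read, and the only evidence bearing on it is the limit of > 250000 nM in this assay, at which 1 of the 2 values shown sits.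

Compound 3 `Nc1cccc(/C=C2\SC(=O)N(Cc3ccc(Cl)cc3)C2=O)c1` differs from compound 1 by 4-chlorophenyl in place of 3-fluorophenyl on a saturated chain carbon bound to an amide-type nitrogen in a ring. Among the measured compounds shown here, no measured step touches this place: compound 1 and compound 2 both carry the same 3-fluorophenyl there, so no step of any size is expected from this change beyond the scatter. The expectation rests on compound 1 sitting at its limit. Compound 3 is therefore expected to give about 250000 nM in this assay, within 80000 nM to 800000 nM. The expected step is a number no higher from compound 1 to compound 3 (the limit leaves the size open), and a limit rather than a number is the likely report.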

Compound 3, half-maximal inhibitory concentration: > 250000 nM
Compound 3: only a limit was reported (the forecaster's own chance of this, stated with the estimate: 75%); the middle value lies on the limit itself.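

Among these compounds, compound 1 and compound 3 both stand only at a limit of this assay, so no step between them can be read: the limit of > 250000 nM in this assay, at which 2 of the 3 values shown sit. The compounds shown leave open whether 4-chlorophenyl in place of 3-fluorophenyl changes the read-out in this assay at all.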